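This account rests on a few compounds, and the source may have more. Where it says the series, first, only, none or still open, it means among the compounds named here.

Measured compounds:
compound 1, `ClCc1ccccc1Cn1cnc2c(Cl)nc(Cl)nc21`: 580 nM
compound 2, `ClCc1cccc(Cn2cnc3ncnc(Cl)c32)c1`: 6160 nM
compound 3, `ClCc1ccc(Cn2cnc3nc(Cl)nc(Cl)c32)cc1`: 1770 nM

These three compounds were tested in a functional assay on NCI-H522 cells (Homo sapiens) for cytotoxicity, read by sulforhodamine B assay, with a stated time of 48 h; a higher number here means a weaker inhibitor of growth, a lower number a stronger inhibitor of growth. Compound 2 stands at the highest of the three numbers. Its nearest neighbour is compound 3, whose number is lower by a gap that lies beyond the usual scatter; compound 1 is furthest from it, with a still lower number, again beyond the scatter. Compound 2 is also the only one of the three that carries a single chloro on its shared core, while compound 1 and compound 3 each carry two.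

Compound 4, `ClCc1cccc(Cn2cnc3nc(Cl)nc(Cl)c32)c1`, has not yet been measured in this assay. It differs from compound 2 in one place: chloro in place of hydrogen on an aromatic carbon. With this change compound 4 carries the same two chloro groups on the core as compound 1 and compound 3, which both gave lower numbers than compound 2. For the measured compounds named here, no single step between two measured compounds matches this change, so the expected size of the step rests only on that comparison. Compound 4 is therefore expected to give a lower number than compound 2, and the estimated step from compound 2 to compound 4 is a 4.1-fold lower number from compound 2 to compound 4 (0.61 log units; beyond the scatter), beyond the scatter. Compound 4 is estimated at 1500 nM, within a range from 500 nM to 4500 nM.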

Compound 4, concentration for 50% growth inhibition: 1810 nM
Compound 4: middle estimate off by 1.2-fold (0.08 log units), on the low side; low and high end bracket the measured number.
By their numbers in this assay, from the lowest: compound 1; then compounds 3 and 4 (each within the scatter of the next); then compound 2.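

In this assay, putting chloro in place of hydrogen on the aromatic carbon between two ring nitrogen atoms gives a 3.4-fold lower number from compound 2 to compound 4 (0.53 log units; beyond the scatter), a modest step and the only change in a single place that can be read directly among these compounds. For the compounds shown here, it shows that this position is not indifferent to the change, and that the second chloro on the shared core goes with a lower number when nothing else in the structure differs, which the earlier compounds could only suggest. With the chloro in place, compound 4 lies within the usual scatter of compound 3, while the data shown include no measurement that would explain the step.

On these data alone, only hydrogen and chloro are seen at this position, so it remains open whether an amine, a methoxy group or a longer chain there would give a lower or a higher number than chloro does. A single pair also leaves open whether the same change would give a step of similar size in other compounds of this kind.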